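Moving the Nitro Group: Cytotoxicity Expected for Compound 4

The compounds below may be only part of what the source reports. "The series", "measured", "known", "first", "only" and "open" are said of these compounds alone.

Compound 1 `Cc1ccc(NC(=O)CS(=O)(=O)c2nccc(Oc3c(C)cc(C#N)cc3C)n2)cc1`: 7490 nM
Compound 2 `Cc1cc(C#N)cc(C)c1Oc1ccnc(S(=O)(=O)CC(=O)Nc2ccc(F)cc2)n1`: 26100 nM
Compound 3 `Cc1cc(C#N)cc(C)c1Oc1ccnc(S(=O)(=O)CC(=O)Nc2cccc([N+](=O)[O-])c2)n1`: 23600 nM

Three compounds sharing one core were tested in an ADME assay on MT4 cells (Homo sapiens) for cytotoxicity, read by MTT assay, with a stated time of 4 days; a lower number here means that less compound is tolerated, a higher number that more compound is tolerated. Compound 1 gives 7490 nM in this assay; compound 2 gives 26100 nM; compound 3 gives 23600 nM. Compound 3 stands second highest of the three, with a 1.1-fold lower number from compound 2 to compound 3 (0.04 log units; within the scatter), while a 3.2-fold higher number from compound 1 to compound 3 (0.50 log units; beyond the scatter).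

The next compound, compound 4 `Cc1cc(C#N)cc(C)c1Oc1ccnc(S(=O)(=O)CC(=O)Nc2ccc([N+](=O)[O-])cc2)n1`, differs from compound 3 only in the position of one group: 4-nitrophenyl in place of 3-nitrophenyl on an amide-type nitrogen. Among the compounds with values here, no measured step changes the position of a nitro group, so nothing bears on this change directly. The steps that touch the same amide-type nitrogen are a 3.5-fold higher number from compound 1 to compound 2 (0.54 log units; beyond the scatter), a 3.2-fold higher number from compound 1 to compound 3 (0.50 log units; beyond the scatter) and a 1.1-fold lower number from compound 2 to compound 3 (0.04 log units; within the scatter); the two that move beyond the scatter both start from compound 1 and exchange one whole substituent for another, whereas the exchange of 4-fluorophenyl for 3-nitrophenyl stays within the scatter. Since compound 3 and compound 4 keep the same atoms and the same nitrophenyl composition, the author expects a step of a 1.1-fold lower number from compound 3 to compound 4 (0.03 log units; within the scatter), that is, none beyond the scatter. Compound 4 is therefore estimated at 22000 nM, with a range from 10000 nM to 50000 nM.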

Compound 4, half-maximal cytotoxic concentration: 59600 nM
For compound 4 the middle estimate is 2.7-fold (0.43 log units) below the measured one, outside the stated range (above it).
By their numbers in this assay, from the lowest: compound 1; then compounds 3 and 2 (each within the scatter of the next); then compound 4.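

In this assay, within the data shown here, moving the nitro group with no change in atoms gives a 2.5-fold higher number from compound 3 to compound 4 (0.40 log units; beyond the scatter) and so shows for the first time that the arrangement on this amide-type nitrogen's aromatic ring can alter the number, since 3-nitrophenyl and 4-nitrophenyl differ only in how the same atoms are joined. The earlier picture, in which 4-fluorophenyl and 3-nitrophenyl could not be told apart with a 1.1-fold lower number from compound 2 to compound 3 (0.04 log units; within the scatter), does not hold for 4-nitrophenyl, for nitro in place of fluoro on an aromatic carbon gives a 2.3-fold higher number from compound 2 to compound 4 (0.36 log units; beyond the scatter) and thereby separates the two groups. The largest step in the set is an 8.0-fold higher number from compound 1 to compound 4 (0.90 log units; beyond the scatter), and compound 4 now has the highest number of the four, with its steps to all three others beyond the scatter.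

Nothing given here accounts for why 4-nitrophenyl differs from 3-nitrophenyl in this measurement. Going by these compounds, it also remains open whether an amine or a carboxylic acid in the place of the nitro group of compound 4 would keep a number this high in this assay or return it towards those of the other compounds.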